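The source may report more compounds than this note shows. Statements on the series, on what has been measured and on what is new or still open speak of the compounds shown alone.

Measured in an ADME assay on HCT-116 cells (Homo sapiens) for antiproliferative activity; on this read-out lower numbers stand for stronger inhibition and higher numbers for weaker inhibition:
- compound 1 `COc1ccc(C(N)=O)cc1COc1ccc(Cl)c(C)c1`: > 50000 nM
- compound 2 `COc1ccc(C(N)=O)cc1/C=C\c1ccc(Cl)cc1`: 29000 nM
- compound 3 `COc1ccc(C(N)=O)cc1/C=C/c1ccccc1`: 36000 nM

Compound 1 gives > 50000 nM, which is a limit of the assay and not a number. Within the data shown here, compound 3, at 36000 nM, lies within the scatter of compound 2, at 29000 nM, and these are the only two numbers.

Compound 4 `COc1ccc(C(N)=O)cc1/C=C/c1ccc([N+](=O)[O-])cc1` follows from compound 3 with nitro in place of hydrogen on an aromatic carbon, para to a large group: nitro in place of hydrogen on an aromatic carbon. Among the measured compounds shown here, no measured pair isolates a change of this kind, so in this assay no step beyond the scatter is expected, in either direction. The estimated step is a 1.3-fold lower number from compound 3 to compound 4 (0.11 log units; within the scatter). For compound 4 the expected value is 28000 nM, with an estimated range of 10000 nM to 50000 nM.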

Compound 4, half-maximal inhibitory concentration: 22000 nM
Estimate against measurement, compound 4: 1.3-fold (0.10 log units) above, and the stated range covers the measured number.
By their numbers in this assay, from the lowest: compounds 4, 2 and 3 (each within the scatter of the next). At a limit, above all of these: compound 1.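

Nitro in place of hydrogen on an aromatic carbon, para to a large group, gives a 1.6-fold lower number from compound 3 to compound 4 (0.21 log units; within the scatter) in this assay and is the first single-place change readable in the series. This position takes a group of 3 heavy atoms with no step beyond the scatter. Compound 4 keeps a number and does not sit at the limit of the read-out: the limit of > 50000 nM in this assay, at which 1 of the 4 values shown sits.

Going by these compounds, whether an amine or a carboxylic acid at this position would move the number beyond the scatter remains open. Also open, on these data alone, is whether a methoxy group or a chlorine here would give a different result.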